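This account rests on a few compounds, and the source may have more. Where it says the series, first, only, none or still open, it means among the compounds named here.

In a functional assay on ECa-109 cells for inhibition, with ECa-109 cell line (Homo sapiens) as the target, read by sulforhodamine B assay (a lower number here means a stronger inhibitor, a higher number a weaker inhibitor), three compounds sharing one core have been measured. Compound 3 `O=C1C=C(Nc2cccc(F)c2)C(=O)c2c1nc1n2[C@H]2OC[C@@H](O)[C@H]2OC1` gives 7030 nM as the higher of the two actual numbers, and compound 2 `CCc1ccc(NC2=CC(=O)c3nc4n(c3C2=O)[C@H]2OC[C@@H](O)[C@H]2OC4)cc1` gives 3080 nM as the other. Compound 1 `O=C1C=C(N2CCC2)C(=O)c2c1nc1n2[C@H]2OC[C@@H](O)[C@H]2OC1` reads > 16000 nM in this assay, and this is a limit of the assay, not a number.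

Compound 4 `CCCN(CCC)C1=CC(=O)c2nc3n(c2C1=O)[C@H]1OC[C@@H](O)[C@H]1OC3` has not yet been measured. It differs from compound 3 by having dipropylamino in place of (3-fluorophenyl)amino on a double-bonded ring carbon. Like the azetidin-1-yl of compound 1, the entering group is not an arylamino group, so the steps away from compound 1 are the closest guide. Putting (3-fluorophenyl)amino in place of azetidin-1-yl gave an at least 2.2-fold lower number from compound 1 to compound 3 (0.35 log units; beyond the scatter) and putting (4-ethylphenyl)amino there gave an at least 5.1-fold lower number from compound 1 to compound 2 (0.71 log units; beyond the scatter) on the same scale. Both are bounds rather than exact sizes. Changing only the aryl group gave a 2.3-fold higher number from compound 2 to compound 3 (0.36 log units; beyond the scatter) and shows that the outcome also depends on which aryl group is present.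

Losing the arylamino group is therefore expected to move the number upward by a modest amount. In this assay the estimated step is a 2.1-fold higher number from compound 3 to compound 4 (0.33 log units; beyond the scatter) toward weaker inhibition. In this assay the estimate for compound 4 is 15000 nM within an expected range of 6000 nM to 38000 nM at this stage.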

Compound 4, half-maximal inhibitory concentration: > 16000 nM
Compound 4: only a limit was reported (the forecaster's own chance of this, stated with the estimate: 40%); middle value at least 1.0-fold (0.02 log units) from the limit.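

In this assay, dipropylamino in place of (3-fluorophenyl)amino gives an at least 2.2-fold higher number from compound 3 to compound 4 (0.35 log units; beyond the scatter), and dipropylamino in place of (4-ethylphenyl)amino gives an at least 5.1-fold higher number from compound 2 to compound 4 (0.71 log units; beyond the scatter). Until now azetidin-1-yl was the only group without an aromatic ring at this double-bonded ring carbon, and the open-chain dipropylamino now shows the same separation from the two arylamino compounds, so among these four compounds only compound 2 and compound 3 give actual numbers, and no compound goes against this. Compound 1 and compound 4 both stand at a limit of the assay, so the step between them cannot be read and the order of azetidin-1-yl and dipropylamino stays unknown: the limit of > 16000 nM in this assay, at which 2 of the 4 values shown sit.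

The change from an arylamino group to dipropylamino removes the aromatic ring and the amine hydrogen together, so the compounds shown cannot say which of the two loses the measured inhibition. Propylamino, which keeps the amine hydrogen without a ring, and methyl(phenyl)amino, which keeps the ring without that hydrogen, would separate them, and it also remains open how far other aryl groups would move the number.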